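The source may report more compounds than this note shows. Statements on the series, on what has been measured and on what is new or still open speak of the compounds shown alone.

Compounds measured so far in a functional assay on RS4-11 cells (Homo sapiens) for inhibition, read by CCK-8 assay, with a stated time of 48 h; on this read-out lower numbers stand for stronger inhibition and higher numbers for weaker inhibition:

- Compound 1 `COc1ccc(S(=O)(=O)Nc2cccc(/C=C(\C#N)C(=O)Nc3nnc(-c4cccs4)s3)c2)cc1`: > 20000 nM
- Compound 2 `COc1ccc(S(=O)(=O)Oc2ccccc2/C=C(\C#N)C(=O)Nc2nnc(Cc3cccc4ccccc34)s2)cc1`: 1360 nM

Compound 1 has the entry > 20000 nM, which is a limit of the assay and not a number, as the limit of > 20000 nM in this assay, at which 1 of the 2 values shown sits, records. Going by the values given here, compound 2 therefore holds the only true number so far, 1360 nM, and it gives a single fixed point on the scale rather than a trend.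

The next compound is compound 3 `COc1ccc(S(=O)(=O)Oc2ccccc2/C=C(\C#N)C(=O)Nc2nnc(Cc3cccc(F)c3)s2)cc1`. It keeps everything in compound 2 except one group, with 3-fluorophenyl in place of naphthalen-1-yl on a saturated chain carbon bound to an aromatic carbon. Put another way, (naphthalen-1-yl)methyl becomes 3-fluorobenzyl.

Among the compounds with values here, no measured pair shows what such a swap does in this assay, so any forecast must lean on compound 2 at 1360 nM and stay cautious. A modest loss of inhibition is the expectation, and the estimated change is a 1.8-fold higher number from compound 2 to compound 3 (0.26 log units; within the scatter). For compound 3 the expected value is 2500 nM, with an estimated range from 700 nM to 10000 nM.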

Compound 3, half-maximal inhibitory concentration: 1210 nM
The estimate for compound 3 lay 2.1-fold (0.32 log units) above the measured number; the measured number falls inside the stated range.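

In this assay, replacing (naphthalen-1-yl)methyl with 3-fluorobenzyl gives a 1.1-fold lower number from compound 2 to compound 3 (0.05 log units; within the scatter), so the read-out stays level even though the group on this saturated chain carbon goes from two six-membered aromatic rings to one, and from 10 heavy atoms to 7, one of them fluorine. Going by these compounds alone, until now the series offered only one true number, which could show no response to any change; this pair is the first direct comparison, and it shows that this position tolerates this particular swap without a readable gain or loss of inhibition. Nothing shown here explains why the two groups give such similar results.

This single pair cannot separate the effect of losing the second ring from that of adding fluorine, and a plain phenyl group at this position would be needed to tell the two apart. It also leaves open whether an aromatic ring is needed here at all, a question that a carboxylic acid, an amine or a longer saturated chain in its place could address.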